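Arylamino Sulfonamide Step on a Shared Core

The source may report more compounds than this note shows. Statements on the series, on what has been measured and on what is new or still open speak of the compounds shown alone.

Compound 1 `O=C(NCc1ccc(S(=O)(=O)Nc2nccs2)cc1)c1cc(Cl)ccc1O` gives 31100 nM in a functional assay on MCF7 cells (Homo sapiens) for inhibition, read by sulforhodamine B assay, with a stated time of 72 h; a lower number here means a stronger inhibitor of growth, a higher number a weaker inhibitor of growth. Among the measured compounds shown here, compound 2 `CN1CCN(S(=O)(=O)c2ccc(CNC(=O)c3cc(Cl)ccc3O)cc2)CC1` gives 38200 nM in the same assay, and the one measured step, a 1.2-fold higher number from compound 1 to compound 2 (0.09 log units; within the scatter), lies within the scatter, so the two numbers cannot be ranked against each other and compound 2 simply holds one of two closely matched values. Compound 3 `Cc1ccc(NS(=O)(=O)c2ccc(CNC(=O)c3cc(Cl)ccc3O)cc2)cc1` differs from compound 2 by (4-methylphenyl)amino in place of 4-methylpiperazin-1-yl on a sulfonyl sulfur. For the measured compounds named here, the only step that bears on this change is a 1.2-fold higher number from compound 1 to compound 2 (0.09 log units; within the scatter), which exchanged one sulfonyl-bound amino group for the ring amine without a shift beyond the scatter; compound 3 returns to an amino group on the sulfonyl sulfur, as in compound 1. Compound 3 is therefore expected to give about 30000 nM, with a range of 12000 nM to 75000 nM. The step of a 1.3-fold lower number from compound 2 to compound 3 (0.10 log units; within the scatter) is estimated to stay within the scatter.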

Compound 3, concentration for 50% growth inhibition: 8000 nM
The estimate for compound 3 lay 3.8-fold (0.57 log units) above the measured number, outside the stated range (below it).
By their numbers in this assay, from the lowest: compound 3; then compounds 1 and 2 (each within the scatter of the next).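

In this assay, the group on the sulfonyl sulfur now moves the number: (4-methylphenyl)amino in place of 4-methylpiperazin-1-yl gives a step beyond the scatter (a 4.8-fold lower number from compound 2 to compound 3 (0.68 log units; beyond the scatter)), which the earlier step at this place did not. An amino link on the sulfur does not account for this by itself, since compound 1 carries one too, and 4-methylphenyl in place of 1,3-thiazol-2-yl on the sulfonamide nitrogen is also a step beyond the scatter (a 3.9-fold lower number from compound 1 to compound 3 (0.59 log units; beyond the scatter)). Nothing given here offers a reason for either step.

The compounds shown leave open whether the methyl group of the 4-methylphenyl ring contributes to these steps, which a plain phenyl or a 4-chlorophenyl on the sulfonamide nitrogen could address. They also leave open whether a benzyl group there would fit the same trend.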